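Varying the distal aryl group in a bombesin receptor subtype-3 agonist series

The compounds below may be only part of what the source reports. "The series", "measured", "known", "first", "only" and "open" are said of these compounds alone.

Measured compounds:
- compound 1, `CCC(C)(C)Cc1c[nH]c(CCc2ccc(-c3ccc(F)cn3)cc2)n1`: 16 nM
- compound 2, `CCC(C)(C)Cc1c[nH]c(CCc2ccc(-c3cccc(N)n3)cc2)n1`: 3.9 nM
- compound 3, `CCC(C)(C)Cc1c[nH]c(CCc2ccc(-c3cnsc3)cc2)n1`: 6.9 nM

All three compounds share the same core and differ only in the aromatic group attached to the phenyl ring. In a functional assay on HEK293 cells for agonist activity at Bombesin receptor subtype-3 (Mus musculus), read by luminescence and calcium flux, with a stated time of 10 min (a lower number here means that less compound is needed, a higher number that more compound is needed for the effect), compound 1 gives 16 nM. In this assay compound 2 gives 3.9 nM, and compound 3 gives 6.9 nM. Compound 3 thus holds the second highest of the three numbers: it is separated from compound 2 by a step within the scatter, and from compound 1 by a step beyond it, a 2.3-fold lower number from compound 1 to compound 3 (0.37 log units; beyond the scatter).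

The unmeasured compound 4, `CCC(C)(C)Cc1c[nH]c(CCc2ccc(-c3cccnc3C(=O)O)cc2)n1`, carries a different group at that position: 2-carboxypyridin-3-yl in place of 1,2-thiazol-4-yl on an aromatic carbon. Of the measured steps, a 4.1-fold lower number from compound 1 to compound 2 (0.61 log units; beyond the scatter) and a 2.3-fold lower number from compound 1 to compound 3 (0.37 log units; beyond the scatter) show that swapping the aryl group moves the number by modest amounts, while a 1.8-fold higher number from compound 2 to compound 3 (0.25 log units; within the scatter) stays within the scatter. None of these steps introduces a carboxylic acid, so the bearing of the measured steps on the new change is indirect. The expectation for compound 4 in this assay is a somewhat higher number, with a 2.9-fold higher number from compound 3 to compound 4 (0.46 log units; beyond the scatter), estimated at 20 nM and expected to fall between 5 nM and 80 nM.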

Compound 4, half-maximal effective concentration: 14 nM
Compound 4: the middle estimate sits 1.4-fold (0.15 log units) above what was measured, within the range that was stated.
By their numbers in this assay, from the lowest: compounds 2 and 3 (each within the scatter of the next); then compounds 4 and 1 (each within the scatter of the next).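

Until now, the groups at this position carried no carboxylic acid, and 2-carboxypyridin-3-yl shows that one can sit there while the compound stays in the same range in this assay, with only modest steps of a 2.0-fold higher number from compound 3 to compound 4 (0.31 log units; beyond the scatter) and a 3.6-fold higher number from compound 2 to compound 4 (0.56 log units; beyond the scatter). The closest comparison is with the 5-fluoropyridin-2-yl group, where a 1.1-fold lower number from compound 1 to compound 4 (0.06 log units; within the scatter) leaves the two groups indistinguishable in this read-out, so adding the carboxylic acid does not set compound 4 apart from compound 1. Nothing available here explains why the numbers fall where they do.

Compared with compound 3, compound 4 changes the ring type, the size of the group and the number of hydrogen-bond donors in a single step, so the compounds shown cannot assign the modest rise to any one of these. A plain pyridine ring with no substituent, or a methyl ester or primary amide in place of the carboxylic acid, would help separate the contribution of the ring from that of the acid, and the compounds here leave open how either would behave.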